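Trifluoromethyl gives way to methoxy in compound 4

The source may hold more compounds than are shown below. What is called first, only, known or untested is meant among the compounds shown, and "the series" means these compounds.

Measured so far in an ADME assay on cells (Hepatocyte, Homo sapiens) for metabolic stability; on this read-out lower numbers stand for a shorter-lived compound and higher numbers for a longer-lived compound:
- compound 1 `O=C(OC1CCC(CN2CCN(c3cc(=O)c4cc(C(F)(F)F)cc([N+](=O)[O-])c4s3)CC2)CC1)c1ccccc1`: 0.603 h
- compound 2 `Cc1ccc(C(=O)OC2CCC(CN3CCN(c4cc(=O)c5cc(C(F)(F)F)cc([N+](=O)[O-])c5s4)CC3)CC2)cc1`: 0.148 h
- compound 3 `O=C(OC1CCC(CN2CCN(c3cc(=O)c4cc(C(F)(F)F)cc([N+](=O)[O-])c4s3)CC2)CC1)c1ccc(C(F)(F)F)cc1`: 0.117 h

Two steps place compound 3 on these numbers: a 5.2-fold lower number from compound 1 to compound 3 (0.71 log units; beyond the scatter), and a 1.3-fold lower number from compound 2 to compound 3 (0.10 log units; within the scatter). It therefore shares the short-lived end of this small set with compound 2, and the two cannot be told apart.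

Compound 4 `COc1ccc(C(=O)OC2CCC(CN3CCN(c4cc(=O)c5cc(C(F)(F)F)cc([N+](=O)[O-])c5s4)CC3)CC2)cc1` changes one group of compound 3: methoxy in place of trifluoromethyl on an aromatic carbon. This puts methoxy in place of trifluoromethyl on an aromatic carbon, para to a large group.

Among the measured compounds shown here, no measured compound carries methoxy, so the evidence is indirect. The nearest guides are a 4.1-fold lower number from compound 1 to compound 2 (0.61 log units; beyond the scatter) and a 5.2-fold lower number from compound 1 to compound 3 (0.71 log units; beyond the scatter), both modest drops of similar size when hydrogen at this place is replaced. Swapping one of those groups for the other gave a 1.3-fold lower number from compound 2 to compound 3 (0.10 log units; within the scatter). Methoxy is therefore expected to stay close to compound 2 and compound 3, well short of compound 1, with at most a slight rise and nothing beyond the scatter.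

The expected change is a 1.5-fold higher number from compound 3 to compound 4 (0.16 log units; within the scatter).

Compound 4 is estimated at 0.17 h, within an expected range of 0.08 h to 0.4 h.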

Compound 4, half-life: 0.165 h
Compound 4: middle estimate off by 1.0-fold (0.01 log units), on the high side, within the range that was stated.
By their numbers in this assay, from the lowest: compounds 3, 2 and 4 (each within the scatter of the next); then compound 1.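

In this assay, methoxy is a third group on this aromatic carbon, para to a large group, to sit well under the plain hydrogen of compound 1, with a 3.7-fold lower number from compound 1 to compound 4 (0.56 log units; beyond the scatter) in the measured half-life. Among the three groups the choice makes no readable difference, with a 1.4-fold higher number from compound 3 to compound 4 (0.15 log units; within the scatter) and a 1.1-fold higher number from compound 2 to compound 4 (0.05 log units; within the scatter), even though trifluoromethyl brings four heavy atoms and methoxy two, one of them a hydrogen-bond acceptor; across these four compounds, then, the drop goes with replacing hydrogen here by any of the three groups rather than with which one is used, and no compound shown goes against this. Nothing shown here explains why the half-life falls when the hydrogen is replaced.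

Going by these compounds, it remains open whether the same low level would hold for a different kind of group at this place, such as an amine, a carboxylic acid or a single fluorine atom. On these data alone, it also remains open whether methoxy on a different carbon of this ring would stay closer to compound 1 than to compound 4.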